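The source may report more compounds than this note shows. Statements on the series, on what has been measured and on what is new or still open speak of the compounds shown alone.

Measured in a functional assay on SMMC-7721 cells (Homo sapiens) for cytotoxicity, read by MTT assay, with a stated time of 24 h; on this read-out lower numbers stand for stronger inhibition and higher numbers for weaker inhibition:
- compound 1 `COc1cc(/C=C2\CN(S(=O)(=O)c3ccc(F)cc3)C/C(=C\c3cc(OC)cc(OC)c3)C2=O)cc(OC)c1` gives 8210 nM
- compound 2 `O=C1/C(=C/c2cccc([N+](=O)[O-])c2)CN(S(=O)(=O)c2ccc(F)cc2)C/C1=C\c1ccccc1F` gives 7820 nM
- compound 3 `N#Cc1ccc(/C=C2\CN(S(=O)(=O)c3ccc(F)cc3)C/C(=C\c3ccccc3F)C2=O)cc1` gives 10300 nM

Compound 3 at 10300 nM lies within the scatter of both compound 1 and compound 2, so the three values form no order. The next structure is compound 4 `COc1cc(/C=C2\CN(S(=O)(=O)c3ccc(F)cc3)C/C(=C\c3ccccc3F)C2=O)cc(OC)c1`, with this change: 3,5-dimethoxyphenyl in place of 4-cyanophenyl on a double-bonded chain carbon bound to a double-bonded ring carbon. Within the data shown here, the only measured step at this place is a 1.3-fold higher number from compound 2 to compound 3 (0.12 log units; within the scatter), which stays within the scatter. Compound 1 carries the same 3,5-dimethoxyphenyl and gives 8210 nM, but it also differs from compound 4 elsewhere. No step beyond the scatter is therefore expected in this assay. The expected step is a 1.2-fold lower number from compound 3 to compound 4 (0.07 log units; within the scatter). For compound 4 the estimated value is 8800 nM, with an expected range from 5000 nM to 15000 nM.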

Compound 4, half-maximal inhibitory concentration: 6890 nM
Estimate against measurement, compound 4: 1.3-fold (0.11 log units) above, and the stated range covers the measured number.
By their numbers in this assay, from the lowest: compounds 4, 2, 1 and 3 (each within the scatter of the next).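

In this assay, 3,5-dimethoxyphenyl on a double-bonded chain carbon bound to a double-bonded ring carbon stays within the scatter of 4-cyanophenyl, with a 1.5-fold lower number from compound 3 to compound 4 (0.17 log units; within the scatter), and of 3-nitrophenyl, with a 1.1-fold lower number from compound 2 to compound 4 (0.05 log units; within the scatter). These three groups are therefore not told apart at this place. The change to 2-fluorophenyl in place of 3,5-dimethoxyphenyl on a carbon of the same kind also gives no separation, with a 1.2-fold lower number from compound 1 to compound 4 (0.08 log units; within the scatter). No measurement offered here explains these close numbers. As far as these compounds go, whether a carboxylic acid or an amine at this place would give a step beyond the scatter remains open.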